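A few compounds are considered here, and "the series" means these few. Any claim that something is new, unique, unknown or untested is made for them only; others in the source may bear on it.

Of the compounds shown here, three with a shared core have been measured, and a fourth awaits measurement. Compound 1 `CCCCCNc1nc(SC)nc2ncccc12` carries a straight chain on the ring nitrogen. In a functional assay (Nicotiana tabacum) (on this read-out lower numbers stand for stronger inhibition and higher numbers for weaker inhibition), compound 1 gives 650 nM. Compound 2 `CCCCCCNc1nc(SC)nc2ncccc12` differs from it by one change, (methyl in place of hydrogen on a saturated chain carbon, five bonds along the chain from a nitrogen on an aromatic ring), and in this assay compound 2 gives 3330 nM. That change made a 5.1-fold higher number from compound 1 to compound 2 (0.71 log units; beyond the scatter). Compound 3 `COc1ccc(Nc2nc(SC)nc3ncccc23)cc1` replaces the chain with an aromatic ring bearing a methoxy group; in this assay compound 3 gives 9420 nM, the highest of the three numbers. The difference between the core of compound 1 and the core of compound 3 is not broken down here.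

Compound 4 `CCOc1ccc(Nc2nc(SC)nc3ncccc23)cc1` is the unmeasured compound. It differs from compound 3 by methyl in place of hydrogen on a saturated chain carbon bound to an oxygen on an aromatic ring. For the measured compounds named here, this is the same kind of change as the one from compound 1 to compound 2, a methyl in place of a hydrogen, but the place is not the same: there the carbon sat five bonds along the chain from a nitrogen on an aromatic ring, here it is bound to an oxygen on an aromatic ring. Because the earlier step was a 5.1-fold higher number from compound 1 to compound 2 (0.71 log units; beyond the scatter), a weakening is expected again, though a smaller one is estimated for this different place, namely a 2.1-fold higher number from compound 3 to compound 4 (0.33 log units; beyond the scatter). Compound 4 is therefore expected to give about 20000 nM in this assay, most likely between 6000 nM and 60000 nM.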

Compound 4, half-maximal inhibitory concentration: 5420 nM
For compound 4 the middle estimate is 3.7-fold (0.57 log units) above the measured one; the whole stated range lies above it.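

In this assay, the move from methoxy to ethoxy is a 1.7-fold lower number from compound 3 to compound 4 (0.24 log units; within the scatter), so this extra methyl leaves the number indistinguishable from the starting value. A methyl in place of a hydrogen therefore cannot be expected to have the same effect wherever it is added in this series, since the two examples shown do not agree: the same change on two cores in this assay, a 5.1-fold higher number (0.71 log units; beyond the scatter) from compound 1 to compound 2 and a 1.7-fold lower number (0.24 log units; within the scatter) from compound 3 to compound 4, 8.9-fold (0.95 log units) apart, beyond the scatter of two such steps

This does not show that the core alone sets the size of the step, since the two changes also sit in different places, one on a straight chain attached through a nitrogen and the other on a saturated chain carbon bound to an oxygen on an aromatic ring, and a single pair of steps cannot separate those two differences or explain the gap between them.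

As far as these compounds go, it remains open whether a longer chain on the oxygen, such as propoxy, would stay within the scatter of compound 3 and compound 4 or would bring a clear rise like the one seen on the straight chain. From the compounds shown here alone, it is equally open how an amine or a carboxylic acid would read at the end of the straight chain or in place of the methoxy group.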